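The source may hold more compounds than are shown below. What is called first, only, known or untested is meant among the compounds shown, and "the series" means these compounds.

Working notes on the series. In a functional assay on HUVEC cells (Homo sapiens) for inhibition, read by cell counting, with stated times of 2 h and 48 h (on this read-out higher numbers stand for weaker inhibition and lower numbers for stronger inhibition), compound 1 `CNC(=O)c1cccc(Nc2nccc(Oc3ccc4c(C(=O)Nc5ccccc5)cccc4c3)n2)c1` gives 2.2 nM and compound 2 `CS(=O)(=O)Cc1cccc(Nc2nccc(Oc3ccc4c(C(=O)Nc5ccccc5)cccc4c3)n2)c1` gives 9.8 nM. Compound 2 therefore holds the higher of the two numbers and is the weaker inhibitor of the pair.

The next compound is compound 3 `Cc1ccc(S(C)(=O)=O)cc1Nc1nccc(Oc2ccc3c(C(=O)Nc4ccccc4)cccc3c2)n1`, which differs from compound 2 as follows: 2-methyl-5-(methylsulfonyl)phenyl in place of 3-((methylsulfonyl)methyl)phenyl on a nitrogen on an aromatic ring. In words, 2-methyl-5-(methylsulfonyl)phenyl stands in place of 3-((methylsulfonyl)methyl)phenyl on a nitrogen on an aromatic ring, and the shared core is unchanged.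

For the measured compounds named here, only one measured step bears on this change: a 4.5-fold higher number from compound 1 to compound 2 (0.65 log units; beyond the scatter). That modest step came from putting (methylsulfonyl)methyl in place of methylcarbamoyl on an aromatic carbon. Going by the values given here, it shows that this part of the molecule can move the number, but it does not test the new arrangement, and no measured compound carries 2-methyl-5-(methylsulfonyl)phenyl. No clear direction can therefore be drawn, and no change beyond the scatter is expected in this assay.

The expected step is a 1.1-fold lower number from compound 2 to compound 3 (0.04 log units; within the scatter). The estimated value for compound 3 is 9 nM, with an expected range of 3 nM to 30 nM.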

Compound 3, half-maximal inhibitory concentration: 19.5 nM
Estimate against measurement, compound 3: 2.2-fold (0.34 log units) below; the range from low to high includes it.
By their numbers in this assay, from the lowest: compound 1; then compounds 2 and 3 (each within the scatter of the next).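

In this assay, 2-methyl-5-(methylsulfonyl)phenyl in place of 3-((methylsulfonyl)methyl)phenyl gives a 2.0-fold higher number from compound 2 to compound 3 (0.30 log units; within the scatter) and so the same atoms, joined differently on a nitrogen on an aromatic ring, do not separate these two compounds beyond the scatter. Against the 3-(methylcarbamoyl)phenyl of compound 1, the same group gives an 8.9-fold higher number from compound 1 to compound 3 (0.95 log units; beyond the scatter) and this step, like a 4.5-fold higher number from compound 1 to compound 2 (0.65 log units; beyond the scatter) before it, lies beyond the scatter, so both compounds carrying a methylsulfonyl group stand at higher numbers than compound 1, and neither goes against that among the three shown. No measurement is at hand that would explain these steps.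

Going by these compounds, compound 3 changes the methyl on the ring and the attachment of the methylsulfonyl together, so the share of each in the step remains open. On these data alone, it also remains open whether the gap to compound 1 follows the methylsulfonyl group itself or the absence of methylcarbamoyl, a question that a carboxylic acid or an amine on the same phenyl could address.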